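This account rests on a few compounds, and the source may have more. Where it says the series, first, only, none or still open, it means among the compounds named here.

Compound 1 `CCCCCCc1ccc(-c2c(C)[nH]c(=O)n2C2CCCCC2)cc1` gives 13700 nM
Compound 2 `CCCCCCOc1ccc(-c2c(C)[nH]c(=O)n2C2CCCCC2)cc1` gives 8500 nM

Both numbers come from a functional assay on brain (Rattus norvegicus, strain Wistar) for inhibition (on this read-out higher numbers stand for weaker inhibition and lower numbers for stronger inhibition), and the two compounds share the same core. Compound 2 stands level with compound 1 on these numbers. Going by the values given here, the one measured step between them is a 1.6-fold lower number from compound 1 to compound 2 (0.21 log units; within the scatter), so the pair cannot be ranked.

Compound 3 `CCCCCCCOc1ccc(-c2c(C)[nH]c(=O)n2C2CCCCC2)cc1` has not yet been measured. It differs from compound 2 by methyl in place of hydrogen on a saturated chain carbon, six bonds along the chain from an oxygen on an aromatic ring, which makes the chain attached through the oxygen longer. Among the compounds with values here, no measured pair shows this kind of change directly. The closest evidence is the step between compound 1 and compound 2 already given, which is a different edit to the same chain and stayed within the scatter. That is thin support, resting on a single step, but it gives no reason to expect a large move in this assay. As far as these compounds go, no shift beyond the scatter is expected, and the direction remains open. The expected step is a 1.1-fold lower number from compound 2 to compound 3 (0.05 log units; within the scatter). For compound 3 the estimated value is 7500 nM, with an expected range from 3500 nM to 15000 nM.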

Compound 3, half-maximal inhibitory concentration: 11600 nM
Compound 3: the middle estimate sits 1.5-fold (0.19 log units) below what was measured; measured number inside the range.
By their numbers in this assay, from the lowest: compounds 2, 3 and 1 (each within the scatter of the next).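

In (this assay), methyl in place of hydrogen on a saturated chain carbon, six bonds along the chain from an oxygen on an aromatic ring, turns the hexyloxy chain of compound 2 into the heptyloxy chain of compound 3 and gives a step that stays within the scatter (a 1.4-fold higher number from compound 2 to compound 3 (0.14 log units; within the scatter)). Replacing the hexyl chain with a heptyloxy chain also leaves the numbers too close to rank (a 1.2-fold lower number from compound 1 to compound 3 (0.07 log units; within the scatter)), so all three compounds stand level, and neither this added chain carbon nor the swap from hexyl to heptyloxy separates any of them on this read-out. No measurement beyond these numbers bears on why the three compounds stay so close together.

Still open, as far as these compounds go, is whether a much longer chain, or a chain ending in an amine or a carboxylic acid, would move the number clearly beyond the scatter. Going by these compounds alone, also open is whether changes to this chain would behave the same way on a core different from the one these three compounds share.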